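A few compounds are considered here, and "the series" means these few. Any claim that something is new, unique, unknown or untested is made for them only; others in the source may bear on it.

Of the compounds shown here, three sharing one core have been read in a functional assay on MDA-MB-231 cells (Homo sapiens) for antiproliferative activity, read by MTT assay, with a stated time of 72 h; on this read-out higher numbers stand for weaker inhibition and lower numbers for stronger inhibition. Compound 1 `CCn1ccnc1-c1cc(OC)c(OC)c(OC)c1`, with ethyl on the aromatic nitrogen, shows > 100000 nM, which is a limit of the assay and not a number. Compound 2 `COc1cc(-c2nccn2-c2ccc(Br)cc2)cc(OC)c1OC`, with 4-bromophenyl in that place, gives 8400 nM. Compound 3 `COc1ccc(-n2ccnc2-c2cc(OC)c(OC)c(OC)c2)cc1`, with 4-methoxyphenyl there, gives 2700 nM, the lowest number of the three, and its gaps to both others lie beyond the scatter.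

Compound 4 `COc1ccc(-n2ccnc2-c2cc(OC)c(OC)c(OC)c2)cc1O` differs from compound 3 by one change: hydroxy in place of hydrogen on an aromatic carbon. The hydroxy enters ortho to a methoxy group and meta to a large group.

Within the data shown here, no measured step adds a hydroxy, so the evidence is indirect. The two large steps, an at least 11-fold lower number from compound 1 to compound 2 (1.07 log units; beyond the scatter) and an at least 37-fold lower number from compound 1 to compound 3 (1.56 log units; beyond the scatter), replace ethyl outright and say little about so small a change. The closest guide is the modest change on the same aromatic ring, and a modest move to a lower number is expected because a 3.1-fold lower number from compound 2 to compound 3 (0.49 log units; beyond the scatter) went that way. The expected step is a 3.4-fold lower number from compound 3 to compound 4 (0.53 log units; beyond the scatter), although a result within the scatter remains possible. In this assay the estimated value for compound 4 is 800 nM, with an expected range from 80 nM to 5000 nM.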

Compound 4, half-maximal inhibitory concentration: 1900 nM
Compound 4: middle estimate off by 2.4-fold (0.38 log units), on the low side; the measured number falls inside the stated range.
By their numbers in this assay, from the lowest: compounds 4 and 3 (each within the scatter of the next); then compound 2. At a limit, above all of these: compound 1.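

In this assay, hydroxy in place of hydrogen gives a 1.4-fold lower number from compound 3 to compound 4 (0.15 log units; within the scatter), so the two compounds cannot be told apart on this read-out. The earlier steps shown here concerned only the group on the aromatic nitrogen and the swap of bromo for methoxy on its ring, whereas this step shows that an aromatic carbon ortho to a methoxy group and meta to a large group can carry a hydroxy, with its hydrogen-bond donor, while the number stays within the scatter of compound 3. Nothing available here offers a reason for this outcome.

The compounds shown leave open whether an amine, a carboxylic acid or a longer chain such as ethoxy on this same aromatic carbon would also stay within the scatter of compound 3, or whether only a group as small as hydroxy does so. They also leave open whether hydroxy in this place would read the same with bromo instead of the methoxy group, as on the ring of compound 2.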